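Trimming the ethyl group: what to expect for compound 4

The source may report more compounds than this note shows. Statements on the series, on what has been measured and on what is new or still open speak of the compounds shown alone.

Measured compounds:
compound 1 `O=C1C=CC(OCC(F)(F)F)N1c1ccc(C(F)(F)F)cc1` gives 13100 nM in a functional assay on K562 cells (Homo sapiens) for inhibition; a higher number here means a weaker inhibitor, a lower number a stronger inhibitor
compound 2 `CC(C)c1ccc(N2C(=O)C=CC2OCC(F)(F)F)cc1` gives 6620 nM in this assay
compound 3 `CCc1ccc(N2C(=O)C=CC2OCC(F)(F)F)cc1` gives 4470 nM in this assay

Compound 3 holds the lowest number of the three. Its gap to compound 2 is small, a 1.5-fold lower number from compound 2 to compound 3 (0.17 log units; within the scatter), and lies within the scatter, so the two cannot be ranked against each other; only its gap to compound 1, a 2.9-fold lower number from compound 1 to compound 3 (0.47 log units; beyond the scatter), is beyond the scatter.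

Compound 4 `O=C1C=CC(OCC(F)(F)F)N1c1ccccc1` differs from compound 3 in one place: hydrogen in place of ethyl on an aromatic carbon. Among the compounds with values here, two measured steps bear on this. The removal of a methyl from the same chain, a 1.5-fold lower number from compound 2 to compound 3 (0.17 log units; within the scatter), stayed within the scatter, as did the swap of trifluoromethyl for isopropyl, a 2.0-fold lower number from compound 1 to compound 2 (0.30 log units; within the scatter). Changes at this aromatic carbon have thus moved the number little, and stripping the chain away entirely is expected to give no step beyond the scatter, a 1.3-fold higher number from compound 3 to compound 4 (0.13 log units; within the scatter), with the uncertainty leaning toward a somewhat higher number.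

Compound 4 is therefore estimated at 6000 nM in this assay, within a range from 2000 nM to 20000 nM.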

Compound 4, half-maximal inhibitory concentration: 24600 nM
Compound 4: middle estimate off by 4.1-fold (0.61 log units), on the low side, and the stated range ends below it.
By their numbers in this assay, from the lowest: compounds 3, 2, 1 and 4 (each within the scatter of the next, the first and the last beyond it).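

Here the position on the aromatic ring shows a sensitivity that the earlier swaps did not reveal: in this assay, hydrogen in place of ethyl gives a clear step (a 5.5-fold higher number from compound 3 to compound 4 (0.74 log units; beyond the scatter)), and hydrogen in place of isopropyl also does (a 3.7-fold higher number from compound 2 to compound 4 (0.57 log units; beyond the scatter)), although ethyl and isopropyl could not be ranked against each other. Hydrogen and trifluoromethyl cannot be ranked either (a 1.9-fold higher number from compound 1 to compound 4 (0.27 log units; within the scatter)), so ethyl stands apart from both of them, while isopropyl stands apart only from hydrogen. The data shown offer no measurement that explains these differences.

As far as these compounds go, it remains open how a methyl, a longer chain such as butyl, an amine or a carboxylic acid at this position would compare. Whether the same steps would hold on a core other than the shared one is also unknown.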